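A few compounds are considered here, and "the series" means these few. Any claim that something is new, unique, unknown or untested is made for them only; others in the source may bear on it.

Compound 1, `CCCCCC(O)c1cc(OC)c2c(c1OC)C(=O)C=CC2=O`, gives in a functional assay on L1210 cells (Mus musculus) for cytotoxicity (on this read-out higher numbers stand for an effect only at larger amounts of compound and lower numbers for an effect already at smaller amounts), a value of 0.066 ug/mL.
Compound 2, `CCCCCC(O)C1=CC(=O)c2c(OC)ccc(OC)c2C1=O`, gives in this assay a value of 0.378 ug/mL.

Of these two, compound 2 stands at the higher number, and the gap to compound 1 lies beyond the usual scatter of repeated measurements, so compound 2 is the weaker of the pair in this read-out. Compound 3, `CCCCCCC(O)C1=CC(=O)c2c(OC)ccc(OC)c2C1=O`, has not yet been measured. It differs from compound 2 in one place: methyl in place of hydrogen on a saturated chain carbon, six bonds along the chain from a double-bonded ring carbon and an oxygen on a saturated carbon. Put plainly, the saturated chain on the core of compound 2 is lengthened by one methyl group, and everything else stays as it is. No measured pair among these compounds shows what such a lengthening does, so there is no step to lean on. Swapping a hydrogen for a methyl on a chain of this kind is a modest change, and the expectation is that the step of a 1.1-fold higher number from compound 2 to compound 3 (0.02 log units; within the scatter) stays within the scatter, with no clear direction either way. Compound 3 is therefore expected to give about 0.4 ug/mL, within a range of 0.15 ug/mL to 1.1 ug/mL.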

Compound 3, concentration for half-maximal effect: 0.732 ug/mL
The estimate for compound 3 lay 1.8-fold (0.26 log units) below the measured number, and the stated range covers the measured number.
By their numbers in this assay, from the lowest: compound 1; then compounds 2 and 3 (each within the scatter of the next).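

Among these compounds, the step gives the first direct reading of what lengthening the chain does on this core: in this assay, methyl in place of hydrogen on a saturated chain carbon, six bonds along the chain from a double-bonded ring carbon and an oxygen on a saturated carbon, comes with a 1.9-fold higher number from compound 2 to compound 3 (0.29 log units; within the scatter). At this place, then, the added methyl leaves the two compounds indistinguishable on this read-out, so this single change gives no firm sign of either a gain or a loss of cytotoxic effect. Nothing measured here offers an explanation for this result.

One step of this size cannot show how the read-out would respond to a longer chain, or to an amine or a carboxylic acid in place of the entering methyl, so no trend along the chain can be drawn from it. Going by these compounds, it also remains open whether the same lengthening would give a similar step on the core of compound 1, which differs from compound 2 in more than one place.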